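A nitrogen-richer bicycle on the amide of compound 2

The source may report more compounds than this note shows. Statements on the series, on what has been measured and on what is new or still open speak of the compounds shown alone.

Compound 2 `O=C(Nc1ccc2[nH]ccc2n1)[C@H]1CCCN1C(=O)C1(c2cccc(Cl)c2)CCCC1` gives the lowest number of the three measured compounds in an assay on isolated protein for inhibition of histone acetyltransferase p300 (Homo sapiens), with a stated time of 60 min (a higher number here means a weaker inhibitor, a lower number a stronger inhibitor), at 0.159 nM. Going by the values given here, compound 3 `COc1ccc(NC(=O)[C@H]2CCCN2C(=O)C2(c3ccc(Cl)cc3)CCCC2)cc1` gives 7.94 nM and compound 1 `COc1ccc(NC(=O)[C@H]2CCCN2C(=O)C2(c3ccccc3)CCCC2)cc1` gives 79.4 nM; the only single-point step measured, a 10-fold lower number from compound 1 to compound 3 (1.00 log units; beyond the scatter), concerns a chloro in place of hydrogen on an aromatic carbon and not the amide nitrogen. Compound 4 `O=C(Nc1cnc2[nH]ncc2c1)[C@H]1CCCN1C(=O)C1(c2cccc(Cl)c2)CCCC1` differs from compound 2 by a group of 9 heavy atoms (6 carbon, 3 nitrogen; one five-membered aromatic ring with 2 hetero atoms, one six-membered aromatic ring with 1 hetero atom) in place of a group of 9 heavy atoms (7 carbon, 2 nitrogen; one five-membered aromatic ring with 1 hetero atom, one six-membered aromatic ring with 1 hetero atom), on an amide-type nitrogen. Among the compounds with values here, no measured step touches this position, so the size of the change is uncertain; the expectation is for a step of a 3.1-fold higher number from compound 2 to compound 4 (0.50 log units; beyond the scatter) in this assay toward a somewhat higher number. Compound 4 is therefore estimated at 0.5 nM in this assay, within 0.1 nM to 3 nM.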

Compound 4, half-maximal inhibitory concentration: 15.9 nM
Compound 4: middle estimate off by 32-fold (1.50 log units), on the low side, and the stated range ends below it.
By their numbers in this assay, from the lowest: compound 2; then compounds 3 and 4 (each within the scatter of the next); then compound 1.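

At the amide-type nitrogen, the exchange of one group of 9 heavy atoms for another with the same count gives a 100-fold higher number from compound 2 to compound 4 (2.00 log units; beyond the scatter) in this assay. The position therefore responds strongly to the identity of the aromatic rings, even when their size and the number of hydrogen-bond donors stay the same. No evidence on the reason for this step is available.

Whether the extra ring nitrogen or the altered ring arrangement accounts for the step remains open. An indole or a plain pyridine at this position could help separate the two.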